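This account rests on a few compounds, and the source may have more. Where it says the series, first, only, none or still open, it means among the compounds named here.

Measured in an in vitro ADME assay on microsomes from liver (Mus musculus) for pharmacokinetics; a lower number here means slower removal, a higher number faster removal of the compound:
- compound 1 `COc1ccc(CN([C@@H]2CC(F)(F)CCNC2=O)S(=O)(=O)c2ccc(Cl)cc2)cn1`: 72 mL.min-1.g-1
- compound 2 `CC1(C)CCNC(=O)[C@H](N(Cc2ccc(C(=O)NC3CC3)cc2)S(=O)(=O)c2ccc(Cl)cc2)C1`: 655 mL.min-1.g-1

Compound 2 has the higher of the two numbers in this assay, and the gap down to compound 1 is beyond the usual scatter. Compound 1 differs from compound 2 in more than one place, so it gives little guidance here.

Next in the series is compound 3 `CC1(C)CCNC(=O)C(N(Cc2ccc(C(=O)NC3CC3)cc2)S(=O)(=O)c2ccc(Cl)cc2)C1`. The change from compound 2 is the two compounds have the same atoms and bonds; at least one stereo element is drawn with a configuration in one of them and without one in the other: 1 of 1 stereo elements differ; a stereocentre at a saturated ring carbon is drawn R in compound 2 and without a configuration in compound 3. Among the measured compounds shown here, no measured pair shows the effect of such a change, so the expectation rests on compound 2 at 655 mL.min-1.g-1 and on the atoms and bonds being the same. No step beyond the scatter is expected, with a slight drop as the likelier direction. The expected step is a 1.2-fold lower number from compound 2 to compound 3 (0.08 log units; within the scatter). For compound 3 the estimated value is 550 mL.min-1.g-1, with an expected range of 280 mL.min-1.g-1 to 1000 mL.min-1.g-1.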

Compound 3, intrinsic clearance in microsomes: 191 mL.min-1.g-1
Compound 3: middle estimate off by 2.9-fold (0.46 log units), on the high side; the whole stated range lies above it.
By their numbers in this assay, from the lowest: compound 1; then compound 3; then compound 2.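

At this saturated ring carbon, a difference in the drawn configuration alone, with atoms and bonds the same, goes with a shift in this assay: a 3.4-fold lower number from compound 2 to compound 3 (0.54 log units; beyond the scatter). Among the compounds shown here, the earlier compounds offered no pair of this kind, so this is the first sign that the configuration at this position, and not only the substituents, bears on the read-out. The step rests on one pair, and the only structural difference to read it by is this: the fact that one of compounds 2 and 3 is drawn with a defined configuration and the other without, at the place where they differ.

From the compounds shown here alone, the composition of compound 3 at that carbon is not stated, so the value of the opposite configuration alone remains unknown. Going by these compounds, it also remains open whether a step of this size would persist with a carboxylic acid or a morpholine amide in place of the cyclopropyl amide.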